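This account rests on a few compounds, and the source may have more. Where it says the series, first, only, none or still open, it means among the compounds named here.

Four compounds share one core, in which a ketone links a pyridine ring to an acid-bearing side chain and an amine carries an aromatic group and a short saturated chain. Compound 1, `COc1cc(N(CC2CC2)c2ccc(Cl)c3ccccc23)cnc1C(=O)CCCC(=O)O`, carries a cyclopropylmethyl chain, and in an assay on isolated protein for inhibition of leukotriene C4 synthase (Homo sapiens), read by LC-MS, with stated times of 45 min and 20 min (a lower number here means a stronger inhibitor, a higher number a weaker inhibitor), compound 1 stands as "not determined" (no result reported), so no result was reported for compound 1. Compound 2, `CCCN(c1cnc(C(=O)[C@H]2C[C@@H]2C(=O)O)c(OC)c1)c1ccc(F)c2ccccc12`, carries a propyl chain, and in this assay compound 2 gives 7.09 nM. Among the compounds with values here, compound 3, `COc1cc(N(CC(C)C)c2cccc(C(F)(F)F)c2)cnc1C(=O)[C@H]1C[C@@H]1C(=O)O`, carries an isobutyl chain and a trifluoromethyl-substituted aromatic group, and in this assay compound 3 gives 20.6 nM, the higher of the two numbers known so far, and the gap to compound 2 is larger than the usual scatter.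

Compound 4, `CCN(c1cccc(C(F)(F)F)c1)c1cnc(C(=O)[C@H]2C[C@@H]2C(=O)O)c(OC)c1`, differs from compound 3 in one place: methyl in place of isopropyl on a saturated chain carbon bound to a nitrogen on an aromatic ring. The shortened chain leaves the rest untouched. Within the data shown here, no measured pair shows this exact change, so the step can only be guessed. The expectation is a small move toward a higher number, or none beyond the scatter, estimated as a 1.5-fold higher number from compound 3 to compound 4 (0.16 log units; within the scatter). Compound 4 is thus expected to give about 30 nM, most likely between 10 nM and 90 nM.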

Compound 4, half-maximal inhibitory concentration: 113 nM
For compound 4 the middle estimate is 3.8-fold (0.58 log units) below the measured one, and the stated range ends below it.
By their numbers in this assay, from the lowest: compound 2; then compound 3; then compound 4.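

In this assay, going from isopropyl to methyl at this place, which reads as isobutyl to ethyl on the nitrogen, gives a 5.5-fold higher number from compound 3 to compound 4 (0.74 log units; beyond the scatter), so the inhibitor weakens clearly when this chain is shortened. Within the data shown here, the earlier compounds could not show this, as they differ from one another in more than one place, and this pair is the first to isolate the chain alone. Nothing measured here explains the loss of strength.

Two chains on one aromatic group cannot show whether the number keeps falling as the chain grows, or whether a longer chain such as pentyl, or one ending in a hydroxyl group, would do better than isobutyl. Among these compounds, it also remains open whether the same shortening would have a similar effect alongside the other aromatic group, the one in compound 2.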